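Hydroxymethyl for Methyl on a Hydroxamic Acid Series

The source may report more compounds than this note shows. Statements on the series, on what has been measured and on what is new or still open speak of the compounds shown alone.

Two compounds of this set have a measured half-life. Compound 1 `CC(CO)(COc1ccc(-c2ccccc2)cc1)C(=O)NO` in an in vitro ADME assay on cells (Hepatocyte, liver, Homo sapiens) for metabolic stability (a lower number here means that the compound disappears faster, a higher number that the compound lasts longer), gives 1.43 h. Compound 2 `Cc1cc([C@H](O)[C@](C)(OCc2ccc(-c3ccccc3)cc2)C(=O)NO)no1` in this assay gives 0.333 h, the lower of the two numbers, and the gap to compound 1 lies beyond the usual scatter. Compound 3 `C[C@@](OCc1ccc(-c2ccccc2)cc1)(C(=O)NO)[C@@H](O)c1cc(CO)on1` has not been measured yet. It differs from compound 2 in one place: hydroxy in place of hydrogen on a saturated chain carbon bound to an aromatic carbon. For the measured compounds named here, no pair of measured compounds differing in one place is available here, so there is no comparable step on which to rest the size of this change. The writer expects a step from compound 2 to compound 3 of a 1.4-fold higher number from compound 2 to compound 3 (0.13 log units; within the scatter), which would stay within the scatter of the method and tends, if anywhere, slightly upward. For compound 3 he estimates a half-life of 0.45 h, with a plausible range from 0.2 h to 1 h.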

Compound 3, half-life in the Hepatocyte assay: 2.33 h
Compound 3: middle estimate off by 5.2-fold (0.71 log units), on the low side, outside the stated range (above it).
By their numbers in the Hepatocyte assay, from the lowest: compound 2; then compounds 1 and 3 (each within the scatter of the next).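

In the Hepatocyte assay, hydroxymethyl in place of methyl on the 5-methyl-1,2-oxazol-3-yl group gives a 7.0-fold higher number from compound 2 to compound 3 (0.84 log units; beyond the scatter). For the compounds shown here, this is the first step in the set that can be read at a single place, a saturated chain carbon bound to an aromatic carbon, and it shows that this one hydroxy is enough to move the half-life beyond the scatter. In a physicochemical assay for solubility, measured as kinetic solubility, at pH 6.5 (on this read-out higher numbers stand for higher solubility and lower numbers for lower solubility), compound 2 gives 59000 nM and compound 3 gives 130000 nM. The same change also goes with a higher number in the physicochemical assay, so here the two read-outs rise together: the measured solubility of compound 2, 59000 nM, and of compound 3, 130000 nM, a 2.2-fold higher number (0.34 log units; beyond the scatter)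

The compounds shown leave open whether a methoxy, an amine or a carboxylic acid on the same carbon would give a similar step. Resting on one pair, they also leave open whether the step carries over to the core of compound 1.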